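From propyl to isopropyl at a clearance limit

This account rests on a few compounds, and the source may have more. Where it says the series, first, only, none or still open, it means among the compounds named here.

Of the compounds shown here, three with a shared core have been read in an ADME assay (liver) for metabolic stability, with Liver microsome (Homo sapiens) as the target, read by LC-MS, using microsomes and NADPH, with a stated time of 5 min, at 37 degrees C; on this read-out lower numbers stand for slow clearance and higher numbers for fast clearance. Compound 1 (`CCn1c([C@@H](C)NS(=O)(=O)c2cccc(Cl)c2)nc2ccc(C(F)(F)F)cc21`) gives > 100 mL.min-1.g-1, which is a limit of the assay and not a number. Compound 2 (`CCn1c([C@@H](C)NS(=O)(=O)c2cn(C)nc2C)nc2ccc(C(F)(F)F)cc21`) gives 28 mL.min-1.g-1. Compound 3 (`CCCn1ncc(S(=O)(=O)N[C@H](C)c2nc3ccc(C(F)(F)F)cc3n2CC)c1C`) gives > 100 mL.min-1.g-1, again a limit and not a number. Compound 3 therefore stands at the limit of > 100 mL.min-1.g-1 in this assay, at which 2 of the 3 values shown sit.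

Compound 4 (`CCn1c([C@@H](C)NS(=O)(=O)c2cnn(C(C)C)c2C)nc2ccc(C(F)(F)F)cc21`) has the same atoms as compound 3, joined differently: isopropyl in place of propyl on an aromatic nitrogen. In words, isopropyl takes the place of propyl on an aromatic nitrogen.

Within the data shown here, no measured step makes this exact change. The nearest evidence comes from changes to the group on the sulfonyl sulfur: an at least 3.5-fold lower number from compound 1 to compound 2 (0.55 log units; beyond the scatter), and an at least 3.5-fold higher number from compound 2 to compound 3 (0.55 log units; beyond the scatter). By contrast, a step that the two limits leave unreadable from compound 1 to compound 3. Since the atoms stay the same, compound 4 is expected to remain close to compound 3 at > 100 mL.min-1.g-1, rather than to fall to the level of compound 2 at 28 mL.min-1.g-1. No change beyond the scatter is expected, and the estimated step is a number no higher from compound 3 to compound 4 (the limit leaves the size open). The value expected for compound 4 in this assay is 100 mL.min-1.g-1, with an estimated range from 45 mL.min-1.g-1 to 220 mL.min-1.g-1.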

Compound 4, intrinsic clearance in microsomes: > 100 mL.min-1.g-1
Compound 4 was reported as a limit; the forecaster's own chance of this, stated with the estimate: 50%; the middle value lies on the limit itself.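

In this assay compound 4 gives > 100 mL.min-1.g-1, which is a limit of the assay and not a number, so the isopropyl form joins the propyl form of compound 3 at that limit. Among these compounds, the steps that pair compound 4 with compound 1 or compound 3 cannot be read, since both ends are limits, but the one readable step is an at least 3.5-fold higher number from compound 2 to compound 4 (0.55 log units; beyond the scatter), which sets the 1-isopropyl-5-methyl-1H-pyrazol-4-yl group on the sulfonyl sulfur apart from the 1,3-dimethyl-1H-pyrazol-4-yl group of compound 2, as the propyl form already was. With compound 4, the limit now holds most of the values shown: the limit of > 100 mL.min-1.g-1 in this assay, at which 3 of the 4 values shown sit.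

Going by these compounds, how far compound 3 and compound 4 lie past the limit remains unknown, so whether isopropyl and propyl differ at this position cannot be told. Also open, on these data alone, is whether an ethyl group or a 2-hydroxyethyl chain on this aromatic nitrogen would bring the number down, and whether the gap to compound 2 follows from the group on that nitrogen or from where the ring methyl group sits.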